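Alkyl and Ester Substituents on a Triazole Series

This account rests on a few compounds, and the source may have more. Where it says the series, first, only, none or still open, it means among the compounds named here.

Of the compounds shown here, three sharing one core have been measured in an ADME assay on HEK293 cells (Homo sapiens) for cytotoxicity, read by sulforhodamine B assay, with a stated time of 48 h, tested at 10 uM; on this read-out lower numbers stand for less inhibition and higher numbers for more inhibition at the one concentration tested (going by the name of the read-out). Compound 1 `COc1nc2ccc(Br)cc2cc1C(c1ccccc1)n1cc(-c2ccc(Br)cc2)nn1` gives 6.28%. Compound 2 `CCCCc1cn(C(c2ccccc2)c2cc3cc(Br)ccc3nc2OC)nn1` gives -3.47%, and compound 3 `CCOC(=O)c1cn(C(c2ccccc2)c2cc3cc(Br)ccc3nc2OC)nn1` gives 2%. On these numbers compound 3 sits closer to compound 1 than to compound 2, yet both gaps are within the scatter: a number 4.3 percentage points lower from compound 1 to compound 3 (within the scatter) and a number 5.5 percentage points higher from compound 2 to compound 3 (within the scatter), while a number 9.8 percentage points lower from compound 1 to compound 2 (within the scatter). Nothing among the three rises beyond the noise of repeated measurement.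

Compound 4 `CCCCCc1cn(C(c2ccccc2)c2cc3cc(Br)ccc3nc2OC)nn1` has not yet been measured. It differs from compound 3 as follows: pentyl in place of ethoxycarbonyl on an aromatic carbon. Going by the values given here, the step that bears most directly on this change is the one from compound 2 to compound 3, which exchanged butyl for ethoxycarbonyl and stayed within the scatter; the present change runs in the opposite sense, toward pentyl. Among the compounds with values here, since none of the measured steps left the scatter, no step beyond it is expected in this assay here either. The estimated step is a number 3 percentage points lower from compound 3 to compound 4 (within the scatter). For compound 4 the expected value is -1%, within a range from -10% to 8%.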

Compound 4, a percentage reported as inhibition, at one concentration (the size of the read-out at that concentration, not a potency): -2%
Compound 4: the middle estimate sits 1 percentage points above what was measured, and the stated range covers the measured number.
By their numbers in this assay, from the lowest: compounds 2, 4, 3 and 1 (each within the scatter of the next).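

Taking away the ethoxycarbonyl with its 2 hydrogen-bond acceptors and putting pentyl, with none, on the same aromatic carbon of the five-membered aromatic ring with 3 nitrogen gives, in this assay, a number 4 percentage points lower from compound 3 to compound 4 (within the scatter). Extending butyl to pentyl gives a number 1.5 percentage points higher from compound 2 to compound 4 (within the scatter), and pentyl in place of 4-bromophenyl gives a number 8.3 percentage points lower from compound 1 to compound 4 (within the scatter), so a second alkyl chain now joins the ester and the aryl group at this position with no step leaving the scatter. Nothing available explains this absence of a step.

The compounds shown leave open whether an amine or a carboxylic acid at this position, or a chain much longer than pentyl, would move the read-out beyond the scatter. They also leave open how any of these groups would behave at a concentration above the single one tested.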